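The source may report more compounds than this note shows. Statements on the series, on what has been measured and on what is new or still open speak of the compounds shown alone.

Among the compounds with values here, compound 1 `CCN(CC)CCNC(=O)c1ccc(C(CC)(CC)c2ccc(OCCC(O)(CC)CC)c(C)c2)n1CC` is the only compound here with a definite number in a functional assay on HepG2 cells (Homo sapiens) for antiproliferative activity, read by MTT assay, with a stated time of 48 h (on this read-out higher numbers stand for weaker inhibition and lower numbers for stronger inhibition), where compound 1 gives 230 nM. Compound 2 `C#CC(C)OC(=O)c1ccc(C(CC)(CC)c2ccc(OCCC(O)(CC)CC)c(C)c2)n1CC` differs from compound 1 at the carbonyl carbon, with (1-methylprop-2-yn-1-yl)oxy in place of (2-(diethylamino)ethyl)amino. In this assay compound 2 gives only > 50000 nM, which is a limit of the measurement rather than a number, as the limit of > 50000 nM in this assay, at which 1 of the 2 values shown sits, shows. That change brought an at least 210-fold higher number from compound 1 to compound 2 (2.33 log units; beyond the scatter).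

Compound 3 `CCn1c(C(=O)NC(C)CO)ccc1C(CC)(CC)c1ccc(OCCC(O)(CC)CC)c(C)c1` keeps the amide of compound 1 and alters only the group on its nitrogen: 1-(hydroxymethyl)ethyl in place of 2-(diethylamino)ethyl on an amide-type nitrogen. Within the data shown here, no measured step changes that group while keeping the amide; the one step measured, an at least 210-fold higher number from compound 1 to compound 2 (2.33 log units; beyond the scatter), removes the amide nitrogen altogether and so bears only loosely on compound 3. A modest weakening, well short of that step, is expected, so that the change from compound 1 to compound 3 is estimated at a 3.9-fold higher number from compound 1 to compound 3 (0.59 log units; beyond the scatter). Compound 3 is thus estimated at 900 nM, within a range of 200 nM to 6000 nM.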

Compound 3, half-maximal inhibitory concentration: 43100 nM
Compound 3: the middle estimate sits 48-fold (1.68 log units) below what was measured; the whole stated range lies below it.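

Keeping the amide is not enough: 1-(hydroxymethyl)ethyl in place of 2-(diethylamino)ethyl on the amide-type nitrogen gives a 190-fold higher number from compound 1 to compound 3 (2.27 log units; beyond the scatter) in this assay, so a large loss on this read-out does not require removing that nitrogen. The value of compound 2 is a limit and not a number: the limit of > 50000 nM in this assay, at which 1 of the 3 values shown sits. The step that rests on this limit reads an at least 1.1-fold lower number from compound 2 to compound 3 (0.06 log units; that floor lies within the scatter), so it sets no order between the amide with 1-(hydroxymethyl)ethyl and the (1-methylprop-2-yn-1-yl)oxy carbonyl.

The compounds shown leave open whether the amine nitrogen of 2-(diethylamino)ethyl or the length of its chain counts more. A plain hexyl chain or a 2-(dimethylamino)ethyl group on the same amide-type nitrogen would help separate the two.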